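The compounds below may be only part of what the source reports. "The series", "measured", "known", "first", "only" and "open" are said of these compounds alone.

Compound 1 `COc1ccc(Cn2c(=O)nc(NCCNC(=N)N)n(Cc3ccc(I)cc3)c2=O)cc1` carries a 4-iodophenyl group, and in a functional assay on the whole organism (strain C57Bl/6) for inhibition, with Mus musculus as the target, with a stated time of 180 min, at 48 degrees C (on this read-out higher numbers stand for an effect only at larger amounts of compound and lower numbers for an effect already at smaller amounts), compound 1 gives 0.039 nM. Compound 2 `COc1ccc(Cn2c(NCCNC(=N)N)nc(=O)n(Cc3ccc([N+](=O)[O-])cc3)c2=O)cc1` gives 0.048 nM, a value within the usual scatter of that of compound 1, while compound 3 `COc1ccc(Cn2c(=O)nc(NCCNC(=N)N)n(Cc3ccc(C)cc3)c2=O)cc1` gives 0.0045 nM. Among these three numbers compound 1 therefore stands second highest, with compound 2 nearest and compound 3 furthest. The only step that joins two of these compounds through a single change is an 8.7-fold lower number from compound 1 to compound 3 (0.94 log units; beyond the scatter). Compound 4 `COc1ccc(Cn2c(=O)nc(NCCNC(=N)N)n(Cc3ccc(Cl)c(Cl)c3)c2=O)cc1` has not yet been measured. It differs from compound 1 by 3,4-dichlorophenyl in place of 4-iodophenyl on a saturated chain carbon bound to an aromatic nitrogen. The change falls on the same 4-iodophenyl group that was exchanged on the way to compound 3, and that exchange gave a step of modest size. Among the measured compounds shown here, no measured pair shows what 3,4-dichlorophenyl does at this place, so the direction stays open, and the estimate rests on compound 1 because of 0.039 nM. Compound 4 is therefore expected to show a 1.3-fold lower number from compound 1 to compound 4 (0.11 log units; within the scatter), a step of little size, giving an estimated 0.03 nM with a range from 0.005 nM to 0.15 nM.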

Compound 4, half-maximal effective concentration: 0.0045 nM
For compound 4 the middle estimate is 6.7-fold (0.82 log units) above the measured one; measured number outside the range, below it.
By their numbers in this assay, from the lowest: compounds 3 and 4 (each within the scatter of the next); then compounds 1 and 2 (each within the scatter of the next).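

In this assay, putting 3,4-dichlorophenyl in place of 4-iodophenyl on the saturated chain carbon bound to an aromatic nitrogen gives an 8.7-fold lower number from compound 1 to compound 4 (0.94 log units; beyond the scatter), so compound 3 is no longer the only case in which replacing the 4-iodophenyl group at this place lowers the number. The two replacements cannot be told apart on this read-out, with no change at the digits printed from compound 3 to compound 4 (within the scatter), even though a 4-methylphenyl group and a 3,4-dichlorophenyl group differ in what they carry on the ring. Nothing available explains why these exchanges lead to this result.

The compounds leave open whether a 4-chlorophenyl group, with a single chlorine, would fall with compound 1 or with compounds 3 and 4. They also leave open how a carboxylic acid or an amine on the ring would behave at this place.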